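The source may report more compounds than this note shows. Statements on the series, on what has been measured and on what is new or still open speak of the compounds shown alone.

Measured in a physicochemical assay for lipophilicity, at pH 7.4; on this read-out higher numbers stand for higher lipophilicity and lower numbers for lower lipophilicity:
- compound 1 `CNC(=O)c1cc(C(=O)N[C@H]2[C@@H]3C[C@@H](O)C[C@@H]32)cc2c1OC[C@H]2c1ccccc1`: 2.9
- compound 2 `CNC(=O)c1cc(C(=O)N[C@@H]2C[C@H]2C)cc2c1O[C@H](CF)[C@H]2c1ccccc1`: 4.5

Of these two, compound 2 stands higher, at 4.5, and the gap to compound 1 lies beyond the scatter. The next compound, compound 3 `CNC(=O)c1cc(C(=O)NC2CC2)cc2c1O[C@H](CF)[C@H]2c1ccccc1`, changes one place in compound 2, turning 2-methylcyclopropyl into cyclopropyl: hydrogen in place of methyl on a saturated ring carbon. In words, this is hydrogen in place of methyl on a saturated ring carbon. Among the measured compounds shown here, no measured pair shows this change, so the expectation rests on the structures alone. A modest fall is expected, an estimated a number 0.40 log units lower from compound 2 to compound 3 (beyond the scatter). In this assay, compound 3 is expected at 4.1, with an estimated range from 3.7 to 4.5.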

Compound 3, distribution coefficient: 3.9
Beside the measured number, compound 3's estimate is 0.20 log units above it; low and high end bracket the measured number.
By their numbers in this assay, from the lowest: compound 1; then compound 3; then compound 2.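

Among the compounds shown here, removing the methyl from the three-membered ring gives the first measured step at this position: a number 0.60 log units lower from compound 2 to compound 3 (beyond the scatter) in this assay. This one pair shows that a single methyl on this saturated ring carbon can shift the read-out beyond the usual scatter. Nothing available explains the size of this step. The compounds shown leave open what an ethyl group, a hydroxyl or an amine would do on this ring carbon. They also leave open whether the same change would give a similar step on another core.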